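A few compounds are considered here, and "the series" means these few. Any claim that something is new, unique, unknown or untested is made for them only; others in the source may bear on it.

Among the compounds with values here, compound 2 `N=C(NCCCc1c[nH]cn1)NCCC(c1ccccc1)c1ccccn1` gives 97.7 nM in a functional assay on ileum for antagonist activity at histamine H1 receptor (Cavia porcellus) (a higher number here means weaker binding, a lower number tighter binding), the lowest of the three numbers known here. Compound 1 `N=C(NCCCc1c[nH]cn1)NCCSC(c1ccccc1)c1ccccn1` gives 100 nM in this assay, a number that sits within the scatter of compound 2, so the two cannot be ranked. Compound 3 `COc1ccc(C(CC/N=C(\N)NCCCc2c[nH]cn2)c2ccccn2)cc1` gives 269 nM in this assay, and that gap to compound 2 lies beyond the scatter. Compound 4 `N=C(NCCCc1c[nH]cn1)NCCC(c1ccccn1)c1ccccc1F` differs from compound 2 in one place: fluoro in place of hydrogen on an aromatic carbon. Within the data shown here, no pair of measured compounds shows this kind of exchange, so nothing measured here says how it acts. A small step, in either direction, is the expectation, with a 1.2-fold lower number from compound 2 to compound 4 (0.09 log units; within the scatter) not reaching beyond the scatter. Compound 4 is therefore expected near 80 nM in this assay, between 35 nM and 220 nM.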

Compound 4, dissociation constant: 437 nM
Beside the measured number, compound 4's estimate is 5.5-fold (0.74 log units) below it, and the stated range ends below it.
By their numbers in this assay, from the lowest: compounds 2 and 1 (each within the scatter of the next); then compounds 3 and 4 (each within the scatter of the next).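

In this assay, the exchange of phenyl to 2-fluorophenyl gives a 4.5-fold higher number from compound 2 to compound 4 (0.65 log units; beyond the scatter) and so is not a silent change. A single fluoro on this aromatic carbon, ortho to a large group, is enough to weaken binding, which shows that this position is sensitive to substitution. Nothing given here accounts for the step. Going by these compounds, whether chloro or methyl at this same place would give a similar step remains open. So does whether the same fluoro exchange would act alike in the core of compound 1.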